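Shrinking the acyl group on a bis-amide core

A few compounds are considered here, and "the series" means these few. Any claim that something is new, unique, unknown or untested is made for them only; others in the source may bear on it.

Compound 1 `COc1ccccc1C(=O)Nc1cccc(NC(=O)c2cc(Cl)cc(Cl)c2)c1` carries a 3,5-dichlorophenyl on one of its two amide carbonyls. In an in vitro functional assay on HEK293-A cells for antagonist activity at metabotropic glutamate receptor 5 (Rattus norvegicus), read by calcium flux (a higher number here means a weaker inhibitor, a lower number a stronger inhibitor), compound 1 gives > 30000 nM, which is a limit of the assay rather than a number. Compound 2 `COc1ccccc1C(=O)Nc1cccc(NC(=O)C2CCC2)c1` has cyclobutyl in that position. In this assay compound 2 gives > 30000 nM, again a limit of the assay. The step from compound 1 to compound 2 is therefore a step that the two limits leave unreadable from compound 1 to compound 2. Both values sit at the same point, (the limit of > 30000 nM in this assay, at which 2 of the 2 values shown sit), so compound 1 stands only at a limit, with no measured number to place it against compound 2.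

Compound 3 `COc1ccccc1C(=O)Nc1cccc(NC(=O)C2CC2)c1` makes a closely related change: cyclopropyl in place of 3,5-dichlorophenyl on a carbonyl carbon. For the measured compounds named here, the only step that bears on it is the one from compound 1 to compound 2, whose size the two limits leave unreadable. Cyclobutyl in place of 3,5-dichlorophenyl left compound 2 at the limit, and compound 3 is expected to behave the same way, so the step of a number no higher from compound 1 to compound 3 (the limit leaves the size open) is estimated to stay within the scatter. Compound 3 is therefore estimated at 30000 nM, with a range from 10000 nM to 100000 nM, and most likely reported only as a limit.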

Compound 3, half-maximal inhibitory concentration: > 30000 nM
Compound 3: no number, only a limit; the forecaster's own chance of this, stated with the estimate: 80%; the middle value sits exactly at the limit.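

The steps among compound 1, compound 2 and compound 3 cannot be read, because all three stand at one limit of the assay, not at a number: the limit of > 30000 nM in this assay, at which 3 of the 3 values shown sit. In this assay the compounds shown leave open how strongly each inhibits, and whether 3,5-dichlorophenyl, cyclobutyl and cyclopropyl on the carbonyl carbon differ at all.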